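Growing Methyl to Ethyl on the Shared Core

A few compounds are considered here, and "the series" means these few. Any claim that something is new, unique, unknown or untested is made for them only; others in the source may bear on it.

In an ADME assay on MT2 cells (Homo sapiens) for cytotoxicity (on this read-out lower numbers stand for higher toxicity in this test and higher numbers for lower toxicity in this test), compound 1 `CC(C)=CCOc1cc(Nc2nccc(CO)n2)ccc1Cl` gives 220 nM and compound 2 `CC(C)=CCOc1cc(Nc2nccc(C)n2)ccc1Cl` gives 150 nM. Compound 2 has the lowest of the two numbers, yet the step of a 1.5-fold lower number from compound 1 to compound 2 (0.17 log units; within the scatter) lies within the scatter, so the two stand level. Compound 3 `CCc1ccnc(Nc2ccc(Cl)c(OCC=C(C)C)c2)n1` differs from compound 2 by methyl in place of hydrogen on a saturated chain carbon bound to an aromatic carbon. Going by the values given here, no measured step covers this change; the single known step at the same place stayed within the scatter. The step of no change at the digits printed from compound 2 to compound 3 (within the scatter) is therefore expected to stay within the scatter as well. For compound 3 the value is estimated at 150 nM, with a range from 60 nM to 400 nM.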

Compound 3, half-maximal cytotoxic concentration: 330 nM
Compound 3: the middle estimate sits 2.2-fold (0.34 log units) below what was measured, and the stated range covers the measured number.
By their numbers in this assay, from the lowest: compounds 2, 1 and 3 (each within the scatter of the next, the first and the last beyond it).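

Going by these compounds alone, at this place, on a saturated chain carbon bound to an aromatic carbon, methyl to ethyl gives the first step beyond the scatter in this assay (a 2.2-fold higher number from compound 2 to compound 3 (0.34 log units; beyond the scatter)), though only a modest one. Methyl in place of hydroxy at the same carbon stays within the scatter (a 1.5-fold higher number from compound 1 to compound 3 (0.18 log units; within the scatter)), so compound 3 stands apart from compound 2 alone. No measured evidence bears on the reason for this step. As far as these compounds go, whether a longer chain such as propyl, or an amine, at this carbon would shift the number further remains open.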